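Compound 3 to compound 4: stripping the benzoyl ring

The source may report more compounds than this note shows. Statements on the series, on what has been measured and on what is new or still open speak of the compounds shown alone.

compound 1 `COc1cc(-c2nn(-c3cccc(NC(=O)Nc4ccc(Cl)c(Cl)c4)c3)cc2-c2ccncc2)ccc1Cl`: 3020 nM
compound 2 `COc1cc(-c2nn(-c3cccc(NC(=O)Nc4cccc(C(F)(F)F)c4)c3)cc2-c2ccncc2)ccc1Cl`: 2680 nM
compound 3 `COc1cc(-c2nn(-c3cccc(NC(=O)c4ccc(Cl)c(C(F)(F)F)c4)c3)cc2-c2ccncc2)ccc1Cl`: 31800 nM

All three values come from a functional assay on SK-MEL-5 cells (Homo sapiens) for inhibition, read by sulforhodamine B assay, with a stated time of 48 h; on this read-out higher numbers stand for lower toxicity in this test and lower numbers for higher toxicity in this test. Compound 3 holds the highest number of the set. The next compound, compound 4 `COc1cc(-c2nn(-c3cccc(NC(=O)c4ccccc4)c3)cc2-c2ccncc2)ccc1Cl`, has phenyl in place of 4-chloro-3-(trifluoromethyl)phenyl on a carbonyl carbon. Going by the values given here, no measured step covers this exact loss. The large steps, an 11-fold higher number from compound 1 to compound 3 (1.02 log units; beyond the scatter) and a 12-fold higher number from compound 2 to compound 3 (1.07 log units; beyond the scatter), both remove the amino link and so say little here. The closest guide is the aryl swap in a 1.1-fold lower number from compound 1 to compound 2 (0.05 log units; within the scatter), which lies within the scatter. Only a small upward move is therefore expected, weakly held: a 1.3-fold higher number from compound 3 to compound 4 (0.12 log units; within the scatter). For compound 4 the estimated value is 42000 nM, with an expected range of 18000 nM to 100000 nM.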

Compound 4, concentration lethal to 50% of the cells: 7100 nM
The estimate for compound 4 lay 5.9-fold (0.77 log units) above the measured number, outside the stated range (below it).
By their numbers in this assay, from the lowest: compounds 2 and 1 (each within the scatter of the next); then compound 4; then compound 3.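

On the carbonyl carbon, the aryl group itself moves the number in this assay: phenyl in place of 4-chloro-3-(trifluoromethyl)phenyl gives a 4.5-fold lower number from compound 3 to compound 4 (0.65 log units; beyond the scatter). Even with plain phenyl, the number stays above those of the amino-linked compounds, with a 2.6-fold higher number from compound 2 to compound 4 (0.42 log units; beyond the scatter) and a 2.4-fold higher number from compound 1 to compound 4 (0.37 log units; beyond the scatter). Nothing available accounts for the drop from loss of the chlorine and trifluoromethyl.

On these data alone, whether the chlorine or the trifluoromethyl carries the step remains open. Also open, as far as these compounds go, is how an amine or a carboxylic acid on that phenyl would read in this assay.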